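Swapping Hydroxy for Diethoxymethyl on Compound 1

The source may report more compounds than this note shows. Statements on the series, on what has been measured and on what is new or still open speak of the compounds shown alone.

In a functional assay on MDA-MB-231 cells (Homo sapiens), read by wound healing assay, with a stated time of 24 h (a lower number here means a stronger inhibitor, a higher number a weaker inhibitor), compound 1 `CC(C)=CCC[C@H](C)c1ccc(C)c(CNCCO)c1O` gives > 20000 nM, which is a limit of the assay and not a number. Compound 2 `CCOC(CCN1COc2c([C@@H](C)CCC=C(C)C)ccc(C)c2C1)OCC`, which carries a 3,3-diethoxypropyl chain, gives a true value of 3100 nM. Compound 3 `CCOC(CCNCc1c(C)ccc([C@@H](C)CCC=C(C)C)c1O)OCC` keeps the core of compound 1 but has diethoxymethyl in place of hydroxy on a saturated chain carbon, two bonds along the chain from an amine nitrogen. Since compound 2 reads 3100 nM with that chain, a clear gain in strength is expected, an estimated step of an at least 4.0-fold lower number from compound 1 to compound 3 (0.60 log units; beyond the scatter). The estimate for compound 3 is 5000 nM, within a range of 1500 nM to 18000 nM.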

Compound 3, half-maximal inhibitory concentration: > 20000 nM
Compound 3: no number, only a limit; the forecaster's own chance of this, stated with the estimate: 20%; at least 4.0-fold (0.60 log units) between middle value and limit.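

No step can be read from compound 1 to compound 3, because each gives only a limit and not a number: the limit of > 20000 nM in this assay, at which 2 of the 3 values shown sit.

The compounds shown leave open whether swapping hydroxy for diethoxymethyl changes strength at all, and by how much.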